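The source may report more compounds than this note shows. Statements on the series, on what has been measured and on what is new or still open speak of the compounds shown alone.

Measured so far, in a functional assay on HEK293 cells for agonist activity at Free fatty acid receptor 1 (Homo sapiens), read by fluorescence and calcium flux; on this read-out lower numbers stand for an effect already at smaller amounts and higher numbers for an effect only at larger amounts of compound:
- compound 1 `CC#CC(CC(=O)O)c1ccc(OCc2ccc(C(=O)N3CCN(c4ccccn4)CC3)s2)cc1`: 138 nM
- compound 2 `CC#CC(CC(=O)O)c1ccc(OCc2ccc(C(=O)N3CCN(c4ccc(C)cc4)CC3)s2)cc1`: 211 nM
- compound 3 `CC#CC(CC(=O)O)c1ccc(OCc2ccc(C(=O)N3CCN(c4ccc(Cl)cc4)CC3)s2)cc1`: 133 nM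

Compound 3 holds the lowest of the three numbers, but a 1.0-fold lower number from compound 1 to compound 3 (0.02 log units; within the scatter) and a 1.6-fold lower number from compound 2 to compound 3 (0.20 log units; within the scatter) both fall within the usual scatter, so the three compounds are not separated in this assay.

Compound 4 `CC#CC(CC(=O)O)c1ccc(OCc2ccc(C(=O)N3CCN(c4cccc([N+](=O)[O-])c4)CC3)s2)cc1` differs from compound 3 in one place: 3-nitrophenyl in place of 4-chlorophenyl on an amine nitrogen in a ring. All three measured steps swap the aryl group on that same ring nitrogen, and none moved the number beyond the scatter, including a 1.5-fold higher number from compound 1 to compound 2 (0.18 log units; within the scatter). On that basis no step beyond the scatter is expected in this assay from compound 3 to compound 4, that is a 1.1-fold higher number from compound 3 to compound 4 (0.05 log units; within the scatter). Compound 4 is therefore estimated at 150 nM, with a range of 55 nM to 420 nM.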

Compound 4, half-maximal effective concentration: 187 nM
The estimate for compound 4 lay 1.2-fold (0.10 log units) below the measured number, and the stated range covers the measured number.
By their numbers in this assay, from the lowest: compounds 3, 1, 4 and 2 (each within the scatter of the next).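

On the amine nitrogen in a ring, 3-nitrophenyl stays within the scatter of all three earlier groups (a 1.4-fold higher number from compound 3 to compound 4 (0.15 log units; within the scatter); a 1.1-fold lower number from compound 2 to compound 4 (0.05 log units; within the scatter); a 1.4-fold higher number from compound 1 to compound 4 (0.13 log units; within the scatter)). The insensitivity seen among 4-chlorophenyl, 4-methylphenyl and pyridin-2-yl therefore extends to a group of 9 heavy atoms with 2 hydrogen-bond acceptors. No supporting data bear on the reason for this result.

Still open, from the compounds shown here alone, is whether an amine or a carboxylic acid on the phenyl ring would give a step beyond the scatter. The same question stands for a saturated ring such as cyclohexyl in place of the aryl group.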